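The source may hold more compounds than are shown below. What is called first, only, known or untested is meant among the compounds shown, and "the series" means these compounds.

Measured compounds:
compound 1 `Cn1c(=O)c2c(nc(CCSc3cccc(Br)c3)n2C)n(C)c1=O`: 64100 nM
compound 2 `Cc1cccc(OCc2nc3c(c(=O)n(C)c(=O)n3C)n2C)c1`: 1230 nM
compound 3 `Cn1c(=O)c2c(nc(COc3ccc(Br)cc3)n2C)n(C)c1=O`: 189 nM

The three measured compounds share one core and differ in the group carried on the chain that leaves it. In an in vitro assay on cells for inhibition of Amine oxidase [flavin-containing] B (Homo sapiens), read by coupled enzyme assay, with a stated time of 20 min (on this read-out higher numbers stand for weaker inhibition and lower numbers for stronger inhibition), compound 1 gives 64100 nM, the highest of the three numbers: compound 2 lies nearest with 1230 nM, and compound 3 furthest with 189 nM, both gaps beyond the scatter.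

Compound 4 `Cn1c(=O)c2c(nc(CCSc3ccc(Br)cc3)n2C)n(C)c1=O` is compound 1 with 4-bromophenyl in place of 3-bromophenyl on a sulfur. Within the data shown here, no measured pair shows exactly this move of a bromine around the ring on a sulfur. Among the measured compounds shown here, the one measured step, a 6.5-fold lower number from compound 2 to compound 3 (0.81 log units; beyond the scatter), changes both the substituent and its position on an oxygen-linked ring, so it speaks only loosely to the change at hand; it does show that a 4-bromophenyl in that position gave a clearly lower number than a 3-methylphenyl. On that basis compound 4 is expected to give a somewhat lower number than compound 1, a step of about a 2.6-fold lower number from compound 1 to compound 4 (0.41 log units; beyond the scatter), though a result within the scatter would not surprise. Compound 4 is therefore estimated at 25000 nM, in a range from 8000 nM to 80000 nM.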

Compound 4, half-maximal inhibitory concentration: 124000 nM
Beside the measured number, compound 4's estimate is 5.0-fold (0.70 log units) below it; measured number above the stated range.
By their numbers in this assay, from the lowest: compound 3; then compound 2; then compounds 1 and 4 (each within the scatter of the next).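

In this assay, putting 4-bromophenyl in place of 3-bromophenyl on a sulfur whose other neighbour is a saturated chain carbon gives a 1.9-fold higher number from compound 1 to compound 4 (0.29 log units; within the scatter), so this read-out does not tell the two compounds apart. Among these compounds, this is the first pair in which only the place of the bromine on the ring changes, and on the sulfur that move alone gives no difference beyond the scatter, unlike the earlier step on an oxygen, a 6.5-fold lower number from compound 2 to compound 3 (0.81 log units; beyond the scatter), which changed the substituent and its place together. Nothing available on these compounds bears on this result beyond the numbers themselves.

The compounds shown leave open how much of the gap between the sulfur-linked compounds 1 and 4 and the oxygen-linked compound 3 belongs to the linking atom and how much to the chain, as these differ together. They also leave open whether a chlorophenyl or a methoxyphenyl on the same sulfur, or a shorter chain carrying the 4-bromophenyl sulfanyl group, would move the number beyond the scatter.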